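The source may report more compounds than this note shows. Statements on the series, on what has been measured and on what is new or still open speak of the compounds shown alone.

Measured compounds in the series:
- compound 1, `CC(CCCC(=O)O)c1cccc(OCc2ccc3ccccc3n2)c1`, 90 nM in an assay on membranes from lung (Cavia porcellus) for binding affinity to cysteinyl leukotriene receptor (Homo sapiens); a lower number here means a stronger inhibitor, a higher number a weaker inhibitor
- compound 2, `O=C(O)CCCCc1cccc(OCc2ccc3ccccc3n2)c1`, 100 nM in this assay
- compound 3, `c1cc(OCCCc2nnn[nH]2)cc(OCc2ccc3ccccc3n2)c1`, 42 nM in this assay

Compound 2 gives the highest number of the three in this assay. Its nearest neighbour is compound 1, and the step of a 1.1-fold higher number from compound 1 to compound 2 (0.05 log units; within the scatter) lies within the scatter. Its furthest neighbour is compound 3, and the step of a 2.4-fold lower number from compound 2 to compound 3 (0.38 log units; beyond the scatter) is modest but beyond the scatter.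

Compound 4, `CC(CCc1nnn[nH]1)Cc1cccc(OCc2ccc3ccccc3n2)c1`, is not yet measured. It differs from compound 2 by 3-(1H-tetrazol-5-yl)-1-methylpropyl in place of 3-carboxypropyl on a saturated chain carbon bound to an aromatic carbon. Among the measured compounds shown here, two measured steps bear on this change. The exchange of the carboxylic acid chain for the tetrazole chain is seen in a 2.4-fold lower number from compound 2 to compound 3 (0.38 log units; beyond the scatter) and in a 2.1-fold lower number from compound 1 to compound 3 (0.33 log units; beyond the scatter), both modest and beyond the scatter, both toward a lower number. The methyl on the chain carbon is seen in a 1.1-fold higher number from compound 1 to compound 2 (0.05 log units; within the scatter), within the scatter. The expected step is therefore a 2.2-fold lower number from compound 2 to compound 4 (0.35 log units; beyond the scatter), a modest move toward a lower number in this assay, carried by the tetrazole exchange, with the methyl adding little. The estimate for compound 4 is 45 nM, within a range of 20 nM to 120 nM.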

Compound 4, inhibition constant: 34 nM
Estimate against measurement, compound 4: 1.3-fold (0.12 log units) above, and the stated range covers the measured number.
By their numbers in this assay, from the lowest: compounds 4 and 3 (each within the scatter of the next); then compounds 1 and 2 (each within the scatter of the next).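

In this assay, among the compounds shown here, the exchange of 3-carboxypropyl for 3-(1H-tetrazol-5-yl)-1-methylpropyl gives a 2.9-fold lower number from compound 2 to compound 4 (0.47 log units; beyond the scatter) on a saturated chain carbon bound to an aromatic carbon, so the move toward a lower number is no longer seen only with the 3-(1H-tetrazol-5-yl)propoxy chain of compound 3. Compound 3 and compound 4 lie within the scatter of each other, so these two tetrazole chains cannot be told apart in this series. No measurement shown here accounts for the step.

Going by these compounds, the entering group brings the tetrazole ring and the methyl together, so the share of each in this step remains open. Also open, on these data alone, is whether an amine or a longer chain at this position would keep the number at this level.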